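The source may report more compounds than this note shows. Statements on the series, on what has been measured and on what is new or still open speak of the compounds shown alone.

Measured compounds:
Compound 1 `COc1ccc(/C=C2\CCC/C(=C\c3cc(OC)c(OC)c(OC)c3)C2=O)cc1OC`: 1900 nM
Compound 2 `COc1cc(/C=C2\CCC/C(=C\c3ccccc3F)C2=O)cc(OC)c1OC`: 2200 nM
Compound 3 `COc1cc(/C=C2\CCC/C(=C\c3ccc(O)c(O)c3)C2=O)cc(OC)c1OC`: 3600 nM

In a functional assay on T84 cells (Homo sapiens) for antiproliferative activity, read by MTT assay, with a stated time of 72 h (a higher number here means a weaker inhibitor, a lower number a stronger inhibitor), compound 3 gives the largest of the three numbers shown, yet the steps of a 1.9-fold higher number from compound 1 to compound 3 (0.28 log units; within the scatter) and a 1.6-fold higher number from compound 2 to compound 3 (0.21 log units; within the scatter) both stay within the scatter, so no real order among the three compounds can be read from these values. Compound 4 `COc1cc(/C=C2\CCC/C(=C\c3ccc(O)c(Cl)c3)C2=O)cc(OC)c1OC` differs from compound 3 by chloro in place of hydroxy on an aromatic carbon. Among the measured compounds shown here, no measured pair exchanges a hydroxy for a chloro, so the only guidance comes from the other changes of the same aryl group on the shared core: a 1.2-fold higher number from compound 1 to compound 2 (0.06 log units; within the scatter), a 1.9-fold higher number from compound 1 to compound 3 (0.28 log units; within the scatter) and a 1.6-fold higher number from compound 2 to compound 3 (0.21 log units; within the scatter), none of which moves beyond the scatter. On that basis the expected step is a 1.2-fold lower number from compound 3 to compound 4 (0.08 log units; within the scatter), small and without a clear direction, and the number for compound 4 is not expected to leave the band set by the three measured compounds. Compound 4 is thus estimated in this assay at 3000 nM, with a range from 1200 nM to 8000 nM.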

Compound 4, half-maximal inhibitory concentration: 1800 nM
Estimate against measurement, compound 4: 1.7-fold (0.22 log units) above; the range from low to high includes it.
By their numbers in this assay, from the lowest: compounds 4, 1, 2 and 3 (each within the scatter of the next).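

In this assay, among the compounds shown here, chloro in place of hydroxy on this aromatic carbon, ortho to a hydroxy group, gives the first direct reading of this exchange (a 2.0-fold lower number from compound 3 to compound 4 (0.30 log units; within the scatter)), and even this, the largest of the new steps, does not leave the scatter. The 3-chloro-4-hydroxyphenyl group also stays within the scatter of the other two aryl groups (a 1.2-fold lower number from compound 2 to compound 4 (0.09 log units; within the scatter); a 1.1-fold lower number from compound 1 to compound 4 (0.02 log units; within the scatter)), so all four aryl groups on the shared core remain unresolved from one another. No measurement shown here offers an explanation for this result.

As far as these compounds go, whether an amine or a carboxylic acid on the same carbon would give a step beyond the scatter remains open. So does the part played by the remaining hydroxy group, which a 3-chloro-4-methoxyphenyl group would test.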